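The source may hold more compounds than are shown below. What is called first, only, known or untested is meant among the compounds shown, and "the series" means these compounds.

Compound 1 `CC(C)(C)C(=O)C1=C(O)C(=O)N(c2ccc(-c3ccon3)cc2)C1c1ccccc1OCCO`: in a physicochemical assay for solubility, in phosphate buffer, at pH 6.8 (on this read-out higher numbers stand for higher solubility and lower numbers for lower solubility), compound 1 gives > 50000 nM, a limit of the assay rather than a number.
Compound 2 `Cc1noc(-c2ccc(N3C(=O)C(O)=C(C(=O)C(C)(C)C)C3c3ccccc3OCCO)cc2)n1`: compound 2 gives > 50000 nM, again a limit.
Compound 3 `CC(C)(C)C(=O)C1=C(O)C(=O)N(c2ccc(-c3ccoc3)cc2)C1c1ccccc1OCCO`: compound 3 gives > 50000 nM, also a limit.

Compound 3 therefore stands at the same limit as the two compounds beside it, and the limit of > 50000 nM in this assay, at which 3 of the 3 values shown sit, sums up the whole set. The measured steps that run into compound 3 are a step that the two limits leave unreadable from compound 1 to compound 3 and a step that the two limits leave unreadable from compound 2 to compound 3; neither limit gives a readable size, so no direction can be taken from them.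

Compound 4 `CC(C)(C)C(=O)C1=C(O)C(=O)N(c2ccc(-c3cccs3)cc2)C1c1ccccc1OCCO` differs from compound 3 by one change: thiophen-2-yl in place of furan-3-yl on an aromatic carbon. Among the compounds with values here, because the limit of > 50000 nM in this assay, at which 3 of the 3 values shown sit, holds for every compound measured so far, there is no step among them whose size would argue for a move away from that limit.

The expectation for compound 4 is therefore that it, too, is reported at the limit, with a step that the limit leaves unreadable from compound 3 to compound 4 meaning no step beyond the scatter. Compound 4 is estimated at 60000 nM, with a range from 20000 nM to 200000 nM.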

Compound 4, solubility: 38600 nM
The estimate for compound 4 lay 1.6-fold (0.19 log units) above the measured number, and the stated range covers the measured number.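

Within the data shown here, at this place, on an aromatic carbon of a six-membered aromatic ring of carbon only and para to a large group, thiophen-2-yl gives the first reading in this assay that is a number and not a limit: replacing furan-3-yl gives an at least 1.2-fold lower number from compound 3 to compound 4 (0.11 log units; that floor lies within the scatter). The other two replacements tell the same story, with an at least 1.2-fold lower number from compound 2 to compound 4 (0.11 log units; that floor lies within the scatter) and an at least 1.2-fold lower number from compound 1 to compound 4 (0.11 log units; that floor lies within the scatter), so each of the three steps has only a floor and none is shown to go beyond the scatter. The steps among compound 1, compound 2 and compound 3 cannot be read, and the set as a whole still sits mostly at one limit: the limit of > 50000 nM in this assay, at which 3 of the 4 values shown sit.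

From the compounds shown here alone, how far the true values of compound 1, compound 2 and compound 3 lie from the number of compound 4 stays open, and with it whether the change to thiophen-2-yl moves the read-out at all. Also open, going by these compounds, is what an amine, a carboxylic acid or a longer chain at this place would give, and whether any group here would take the number clearly beyond the scatter.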